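Replacing Nitrophenyl by Methoxyphenyl: What to Expect

The compounds below may be only part of what the source reports. "The series", "measured", "known", "first", "only" and "open" are said of these compounds alone.

Measured so far:
compound 2 `CCN1C(=O)N(CC)C2C1NC(=S)N2/N=C/C=C/c1ccccc1[N+](=O)[O-]` — 15300 nM
compound 1 `COc1ccc(/C=C/C=N/N2C(=S)NC3C2N(C)C(=O)N3C)cc1` — > 100000 nM

Among the measured compounds shown here, in a functional assay on RD cells (Homo sapiens) for inhibition, read by MTT assay, with a stated time of 72 h (on this read-out higher numbers stand for weaker inhibition and lower numbers for stronger inhibition), compound 2 gives 15300 nM, the only actual number among the results. Compound 1 reaches only > 100000 nM, which is a limit of this assay rather than a number.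

Compound 3 `CCN1C(=O)N(CC)C2C1NC(=S)N2/N=C/C=C/c1ccc(OC)cc1` is not yet measured. It differs from compound 2 by 4-methoxyphenyl in place of 2-nitrophenyl on a double-bonded chain carbon bound to a double-bonded chain carbon. Compound 1 carries that same 4-methoxyphenyl and stands at the limit of > 100000 nM in this assay, at which 1 of the 2 values shown sits, so a weakening step is expected from compound 2 to compound 3, a 3.9-fold higher number from compound 2 to compound 3 (0.59 log units; beyond the scatter), beyond the usual scatter. Compound 3 is estimated at 60000 nM, in the range 20000 nM to 150000 nM.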

Compound 3, half-maximal inhibitory concentration: 87000 nM
For compound 3 the middle estimate is 1.5-fold (0.16 log units) below the measured one; the range from low to high includes it.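

In this assay, among the compounds shown here, 4-methoxyphenyl in place of 2-nitrophenyl brings a 5.7-fold higher number from compound 2 to compound 3 (0.75 log units; beyond the scatter), the first readable step at this position, showing that the group placed here changes the result. Compound 3 also gives 4-methoxyphenyl an actual number rather than a limit. Compound 1, which carries the same group, still stands only at a limit: the limit of > 100000 nM in this assay, at which 1 of the 3 values shown sits.

This single step cannot show whether losing the nitro group or gaining the methoxy group matters more. As far as these compounds go, how a plain phenyl ring or an aminophenyl group would behave at this position remains open.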